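A few compounds are considered here, and "the series" means these few. Any claim that something is new, unique, unknown or untested is made for them only; others in the source may bear on it.

Four close analogues are compared in a functional assay on RXF 393 cells (Homo sapiens) for cytotoxicity, read by sulforhodamine B assay, with a stated time of 48 h; a higher number here means that more compound is tolerated, a lower number that less compound is tolerated. Compound 1 `ClCc1ccc(Cn2cnc3c(Cl)ncnc32)cc1` reports only a limit of the assay there, > 100000 nM, which is the limit of > 100000 nM in this assay, at which 1 of the 3 values shown sits. Compound 3 `ClCc1ccc(Cn2cnc3c(Cl)nc(Cl)nc32)cc1` gives 83200 nM in this assay . The change from compound 1 to compound 3 is chloro in place of hydrogen on an aromatic carbon, and it made a step of an at least 1.2-fold lower number from compound 1 to compound 3 (0.07 log units; that floor lies within the scatter). Compound 2 `ClCc1cccc(Cn2cnc3ncnc(Cl)c32)c1` gives 47900 nM in this assay ; the difference between the core of compound 2 and the core of compound 1 is not broken down here. Compound 4 `ClCc1cccc(Cn2cnc3nc(Cl)nc(Cl)c32)c1` is yet to be measured and differs from compound 2 by chloro in place of hydrogen on an aromatic carbon, the same change as that from compound 1 to compound 3, at a place described in the same words. Because the earlier step was an at least 1.2-fold lower number from compound 1 to compound 3 (0.07 log units; that floor lies within the scatter), compound 4 is expected to move from compound 2 by a 1.3-fold lower number from compound 2 to compound 4 (0.12 log units; within the scatter) in this assay . Compound 4 is therefore estimated at 36000 nM, with an expected range from 12000 nM to 100000 nM.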

Compound 4, concentration lethal to 50% of the cells: 5120 nM
Compound 4: middle estimate off by 7.0-fold (0.85 log units), on the high side; the measured number lies below the stated range.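

In this assay, chloro in place of hydrogen on an aromatic carbon gave a 9.4-fold lower number from compound 2 to compound 4 (0.97 log units; beyond the scatter). Set beside the earlier step, this shows that the change can produce a step beyond the scatter on one core, but not that it carries over to another core with the same size, nor that its size depends on the core: the same change on two cores in this assay, an at least 1.2-fold lower number (0.07 log units; that floor lies within the scatter) from compound 1 to compound 3 and a 9.4-fold lower number (0.97 log units; beyond the scatter) from compound 2 to compound 4; the limit leaves it open whether they differ Compound 1 reports only a limit of the assay, so the earlier step has no fixed size: the limit of > 100000 nM in this assay, at which 1 of the 4 values shown sits.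

The compounds shown leave open whether an amine or a methoxy group on that same carbon, between two ring nitrogen atoms, would give a similar step. As far as these compounds go, it also remains open which part of the difference between the two cores goes with the size of the new step.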